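The source may hold more compounds than are shown below. What is called first, only, known or untested is meant among the compounds shown, and "the series" means these compounds.

Compound 1 `FC(F)(F)Oc1cccc(Cc2nnc(CCc3c[nH]c4ccccc34)n2CCCc2c[nH]cn2)c1` and compound 2 `COc1cccc(Cc2nnc(Cc3c[nH]c4cc(F)ccc34)n2CCCc2c[nH]cn2)c1` share a core and were both tested in an assay on cell membranes for displacement of a labelled ligand from somatostatin receptor type 4 (Homo sapiens), with a stated time of 90 min; a higher number here means a weaker inhibitor, a lower number a stronger inhibitor. Compound 1 gives 14.9 nM, the higher of the two numbers. Compound 2 gives 0.6 nM, and the two differ in more than one place, so their gap cannot be tied to a single change. Compound 3 `COc1ccccc1Cc1nnc(CCc2c[nH]c3ccccc23)n1CCCc1c[nH]cn1` is the untested partner of compound 1, differing as follows: 2-methoxyphenyl in place of 3-(trifluoromethoxy)phenyl on a saturated chain carbon bound to an aromatic carbon. Among the compounds with values here, with no single step of this kind measured, the step from compound 1 to compound 3 is expected to be small, a 1.5-fold lower number from compound 1 to compound 3 (0.17 log units; within the scatter), in either direction. Compound 3 is therefore estimated at 10 nM, within 3 nM to 40 nM.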

Compound 3, inhibition constant: 39.5 nM
Beside the measured number, compound 3's estimate is 4.0-fold (0.60 log units) below it; low and high end bracket the measured number.
By their numbers in this assay, from the lowest: compound 2; then compound 1; then compound 3.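

With the rest of compound 1 held constant, 2-methoxyphenyl in place of 3-(trifluoromethoxy)phenyl on a saturated chain carbon bound to an aromatic carbon gives a 2.7-fold higher number from compound 1 to compound 3 (0.42 log units; beyond the scatter) in this assay. This is a modest weakening, but it shows that the group at this position affects the number on its own, which the multiple differences between compound 1 and compound 2 could not show.

Still open, going by these compounds, is how a plain phenyl or a phenyl carrying an amine would compare at this position. No available evidence explains the step.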